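Pyrazoline nitrogen substituent: formyl replaced by phenyl

A few compounds are considered here, and "the series" means these few. Any claim that something is new, unique, unknown or untested is made for them only; others in the source may bear on it.

Working notes on the series. Compound 1 `Cc1ccc(C2=NN(c3ccc([N+](=O)[O-])cc3)C(c3cn(-c4ccccc4)nc3-c3ccc(Cl)c(Cl)c3)C2)cc1` and compound 2 `O=CN1N=C(c2ccc(F)cc2)CC1c1cn(-c2ccccc2)nc1-c1ccc(Cl)c(Cl)c1` have been measured in a functional assay on the whole organism (strain Wistar) for inhibition, with Rattus norvegicus as the target, read by paw edema, with stated times of 30 min and 120 min, at a dose of 50 mg/kg by the oral route; on this read-out higher numbers stand for more inhibition at the one dose given (going by the name of the read-out) and lower numbers for less inhibition. Compound 1 gives 71.9%, while compound 2 gives 60.9%, the lowest of the two numbers; compound 1 sits higher by an amount beyond the scatter, and as the two structures differ in more than one place, only their two values are noted. Compound 3 `Fc1ccc(C2=NN(c3ccccc3)C(c3cn(-c4ccccc4)nc3-c3ccc(Cl)c(Cl)c3)C2)cc1` is not yet measured. It differs from compound 2 in one place: phenyl in place of formyl on an amine nitrogen in a ring. Within the data shown here, no step between measured compounds is known for this change. An aryl group on the ring nitrogen is present in compound 1, which gives 71.9%, so a step upward from compound 2 is expected, but of a size within the usual scatter. Compound 3 is estimated at 66%, within 54% to 78%, which means an expected step of a number 5.1 percentage points higher from compound 2 to compound 3 (within the scatter).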

Compound 3, a percentage reported as inhibition, in the whole organism at one dose (the size of the read-out at that dose, not a potency): 60.2%
Beside the measured number, compound 3's estimate is 5.8 percentage points above it; low and high end bracket the measured number.
By their numbers in this assay, from the lowest: compounds 3 and 2 (each within the scatter of the next); then compound 1.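

In this assay, phenyl in place of formyl on the amine nitrogen in the ring gives a number 0.7 percentage points lower from compound 2 to compound 3 (within the scatter), the first one-place step read at this position. Exchanging formyl, with no ring, for a six-membered aromatic ring of carbon only thus leaves the read-out within the scatter at the single dose, so this position accepts either group without a step that can be told from the scatter. No measurement bears on why the two groups read alike.

Open, on these data alone, is how an acetyl group or a benzyl group on this nitrogen would read. Also open, as far as these compounds go, is whether a nitro group on the new phenyl ring would move the number with the 4-fluorophenyl group kept in place.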